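Naphthalen-2-yl replaces tert-butylphenyl on a weakly cytotoxic scaffold

The source may hold more compounds than are shown below. What is called first, only, known or untested is meant among the compounds shown, and "the series" means these compounds.

Among the measured compounds shown here, in a functional assay on A549 cells (Homo sapiens) for cytotoxicity, read by MTT assay, with a stated time of 48 h (on this read-out higher numbers stand for weaker inhibition and lower numbers for stronger inhibition), compound 1 `C=C(c1ccc(OC)cc1)c1cc(OC)c(OC)c(OC)c1-c1ccccc1` gives 22000 nM and compound 2 `C=C(c1ccc(OC)cc1)c1cc(OC)c(OC)c(OC)c1-c1ccc(C(C)(C)C)cc1` gives 27000 nM so these two cannot be told apart, and compound 2 stands level with its only neighbour. Compound 3 `C=C(c1ccc(OC)cc1)c1cc(OC)c(OC)c(OC)c1-c1ccc2ccccc2c1` differs from compound 2 by naphthalen-2-yl in place of 4-(tert-butyl)phenyl on an aromatic carbon on the shared core. For the measured compounds named here, the one measured step of a 1.2-fold higher number from compound 1 to compound 2 (0.09 log units; within the scatter) is tert-butyl in place of hydrogen on an aromatic carbon, in the group that changes now. Going by the values given here, with only that step as a guide, no change beyond the scatter is expected in either direction, and the estimated move a 1.1-fold lower number from compound 2 to compound 3 (0.05 log units; within the scatter) stays small. For compound 3 the estimated value is 24000 nM within an expected range of 11000 nM to 50000 nM on this read-out.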

Compound 3, half-maximal inhibitory concentration: 15000 nM
The estimate for compound 3 lay 1.6-fold (0.20 log units) above the measured number; the range from low to high includes it.
By their numbers in this assay, from the lowest: compounds 3, 1 and 2 (each within the scatter of the next).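

At this position, ortho to the 1-(4-methoxyphenyl)ethenyl group, naphthalen-2-yl brings a second six-membered aromatic ring, yet in this assay both a 1.8-fold lower number from compound 2 to compound 3 (0.26 log units; within the scatter) and a 1.5-fold lower number from compound 1 to compound 3 (0.17 log units; within the scatter) stay within the scatter. Phenyl, 4-(tert-butyl)phenyl and naphthalen-2-yl therefore cannot be told apart here, so these three all-carbon groups give no ranking. No outside evidence is available to explain this result. Still open, going by these compounds, is whether a group containing nitrogen or oxygen at this position, such as an amine or a carboxylic acid, would give a different reading.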